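A few compounds are considered here, and "the series" means these few. Any claim that something is new, unique, unknown or untested is made for them only; others in the source may bear on it.

Measured so far in a functional assay on HeLa cells (Homo sapiens) for cytotoxicity, read by MTT assay; a lower number here means a stronger inhibitor, a higher number a weaker inhibitor:
Compound 1 `Cc1cn([C@H]2C[C@H](O[Si](C)(C)C(C)(C)C)[C@@H](C3CC(=O)S[S+]3[O-])O2)c(=O)[nH]c1=O` gives 43100 nM
Compound 2 `Cc1cn([C@H]2C[C@H](O)[C@@H](C3CC(=O)SS3)O2)c(=O)[nH]c1=O` gives 299000 nM

Compound 2 has the higher number of the two, and compound 1 lies below it by more than the scatter. Compound 3 `Cc1cn([C@H]2C[C@H](O)[C@@H](C3CC(=O)S[S+]3[O-])O2)c(=O)[nH]c1=O` differs from compound 2 by a group of 7 heavy atoms (3 carbon, 2 oxygen, 2 sulfur; one five-membered non-aromatic ring with 2 hetero atoms) in place of a group of 6 heavy atoms (3 carbon, 1 oxygen, 2 sulfur; one five-membered non-aromatic ring with 2 hetero atoms), on a saturated ring carbon on a saturated ring carbon. Within the data shown here, no measured step isolates this change, so the expectation is loose. Expected in this assay is a 2.7-fold lower number from compound 2 to compound 3 (0.43 log units; beyond the scatter) as an estimate, a moderate move to a lower number, probably just beyond the scatter. For compound 3 the estimated value is 110000 nM with an expected range from 40000 nM to 300000 nM in this measurement.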

Compound 3, half-maximal inhibitory concentration: 119000 nM
The estimate for compound 3 lay 1.1-fold (0.03 log units) below the measured number; the measured number falls inside the stated range.
By their numbers in this assay, from the lowest: compound 1; then compound 3; then compound 2.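

In this assay, the group of 7 heavy atoms in place of the group of 6 heavy atoms on the saturated ring carbon gives a 2.5-fold lower number from compound 2 to compound 3 (0.40 log units; beyond the scatter), so this place alone moves the number. A hydrogen atom in place of the silicon-bearing group of 7 heavy atoms on the oxygen gives a 2.8-fold higher number from compound 1 to compound 3 (0.44 log units; beyond the scatter), which divides the gap between compound 1 and compound 2 into two separate steps, each beyond the scatter. Nothing available explains either step.

Open, from the compounds shown here alone, is whether a methyl or acetyl group on that oxygen moves the number as the silicon-bearing group does. Also open, going by these compounds, is whether an open-chain thioester at the saturated ring carbon would keep a number near that of compound 3.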